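From (3-bromophenyl)carbonyl to (4-methylphenyl)carbamoyl: compound 3

The compounds below may be only part of what the source reports. "The series", "measured", "known", "first", "only" and "open" are said of these compounds alone.

Compound 1 `COc1cc(-c2nnc(SCC(=O)c3ccc(Cl)cc3)n2N)cc(OC)c1OC` and compound 2 `COc1cc(-c2nnc(SCC(=O)c3cccc(Br)c3)n2N)cc(OC)c1OC` share one core and differ only at the carbonyl carbon. In a functional assay on PC-3 cells (Homo sapiens) for antiproliferative activity, read by MTT assay, with a stated time of 48 h (on this read-out lower numbers stand for stronger inhibition and higher numbers for weaker inhibition), compound 1 reaches only the limit > 100000 nM. In this assay compound 2 likewise reaches only the limit > 100000 nM. The step that the two limits leave unreadable from compound 1 to compound 2 therefore cannot be read, since both values sit at the limit of > 100000 nM in this assay, at which 2 of the 2 values shown sit. Compound 2 thus stands at the weak end of what the assay reports, with no number of its own. Compound 3 `COc1cc(-c2nnc(SCC(=O)Nc3ccc(C)cc3)n2N)cc(OC)c1OC` carries the change ((4-methylphenyl)amino in place of 3-bromophenyl on a carbonyl carbon). Going by the values given here, no measured step bears on this change: the only step in hand is unreadable, and both measured compounds sit at the limit, so no direction beyond the scatter can be expected in this assay, and a limit is again the likeliest outcome. For compound 3 the expected value in this assay is 150000 nM, within 30000 nM to 600000 nM. The expected step that the limit leaves unreadable from compound 2 to compound 3 is accordingly close to none.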

Compound 3, half-maximal inhibitory concentration: 43100 nM
Compound 3: the middle estimate sits 3.5-fold (0.54 log units) above what was measured, within the range that was stated.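

Going by these compounds alone, the carbonyl carbon is the first place where a change moves the read-out in this assay: (4-methylphenyl)amino in place of 3-bromophenyl gives an at least 2.3-fold lower number from compound 2 to compound 3 (0.36 log units; beyond the scatter), and the same group in place of 4-chlorophenyl gives an at least 2.3-fold lower number from compound 1 to compound 3 (0.36 log units; beyond the scatter). Within the data shown here, compound 3 thus carries the only true number so far, and the size of the gain is not fixed, whichever aryl group it is set against. Both steps are therefore bounds, and the step between compound 1 and compound 2 still cannot be read: the limit of > 100000 nM in this assay, at which 2 of the 3 values shown sit.

The amino link and the 4-methyl group enter together, so the step cannot yet be assigned to either of them. A plain phenylamino group or a morpholine on the same carbonyl carbon would begin to separate the two.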